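The compounds below may be only part of what the source reports. "The series", "measured", "known", "first", "only" and "open" are said of these compounds alone.

Compound 1 `CC(C)=CCOc1cc(Nc2ncnc(N)n2)ccc1C#N`: 200 nM
Compound 2 `COc1nc(N)nc(Nc2ccc(C#N)c(OCC=C(C)C)c2)n1`: 110 nM

In an ADME assay on MT2 cells (Homo sapiens) for cytotoxicity (a lower number here means that less compound is tolerated, a higher number that more compound is tolerated), compound 1 gives 200 nM and compound 2 gives 110 nM; the two numbers lie close together, as a 1.8-fold lower number from compound 1 to compound 2 (0.26 log units; within the scatter) shows. Compound 3 `CC(C)=CCOc1cc(Nc2nccc(N)n2)ccc1C#N` differs from compound 1 at another place: 4-aminopyrimidin-2-yl in place of 4-amino-1,3,5-triazin-2-yl on a nitrogen on an aromatic ring. Among the measured compounds shown here, no measured step touches this change, and the one step that is known, a 1.8-fold lower number from compound 1 to compound 2 (0.26 log units; within the scatter), concerns a different part of the molecule and stays within the scatter. The expectation is therefore a step no larger than the scatter, no change at the digits printed from compound 1 to compound 3 (within the scatter). For compound 3 the estimate in this assay is 200 nM, with a range from 70 nM to 600 nM.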

Compound 3, half-maximal cytotoxic concentration: 41 nM
The estimate for compound 3 lay 4.9-fold (0.69 log units) above the measured number, and the stated range ends above it.
By their numbers in this assay, from the lowest: compound 3; then compounds 2 and 1 (each within the scatter of the next).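

In this assay, the group on the nitrogen on an aromatic ring proves able to move the number: 4-aminopyrimidin-2-yl in place of 4-amino-1,3,5-triazin-2-yl gives a 4.9-fold lower number from compound 1 to compound 3 (0.69 log units; beyond the scatter), a step beyond the scatter. The only earlier step, the methoxy change, had stayed within the scatter, so this is the first change shown to shift tolerance. Nothing available explains the shift. On these data alone, it remains open whether a methylamino group or a hydroxyl group in place of the amino group on the 4-aminopyrimidin-2-yl ring would move the number further, and whether a methoxy group on that ring would matter.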